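The source may report more compounds than this note shows. Statements on the series, on what has been measured and on what is new or still open speak of the compounds shown alone.

Compound 1 `Cc1ccc(NC(=O)COc2ccc3cc(/C=C4/SC(=O)NC4=O)ccc3c2)cc1` carries a 4-methylphenyl group on an amide-type nitrogen attached to the shared core. In an assay on isolated protein for inhibition of histone deacetylase 4 (Homo sapiens), with a stated time of 1 h (on this read-out higher numbers stand for weaker inhibition and lower numbers for stronger inhibition), compound 1 gives 1700 nM, the second highest of the three numbers measured. Compound 2 `O=C(COc1ccc2cc(/C=C3/SC(=O)NC3=O)ccc2c1)Nc1cccc(F)n1` gives 840 nM in this assay, and compound 3 `O=C(COc1ccc2cc(/C=C3/SC(=O)NC3=O)ccc2c1)Nc1ccc(F)cc1F` gives 3900 nM. The measured steps all exchange the aryl group on that nitrogen: a 2.0-fold lower number from compound 1 to compound 2 (0.31 log units; beyond the scatter) and a 2.3-fold higher number from compound 1 to compound 3 (0.36 log units; beyond the scatter) run in opposite directions, while a 4.6-fold higher number from compound 2 to compound 3 (0.67 log units; beyond the scatter) is the widest gap seen. Compound 4 `O=C(COc1ccc2cc(/C=C3/SC(=O)NC3=O)ccc2c1)Nc1ccccc1` differs from compound 1 by hydrogen in place of methyl on an aromatic carbon. This is a smaller alteration than any measured exchange, each of which replaced the whole ring, so a step no larger than those is expected, possibly within the scatter and with no clear direction. The estimate for compound 4 in this assay is 2000 nM, between 900 nM and 4500 nM, corresponding to an expected step of a 1.2-fold higher number from compound 1 to compound 4 (0.07 log units; within the scatter).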

Compound 4, half-maximal inhibitory concentration: 2100 nM
Compound 4: middle estimate off by 1.1-fold (0.02 log units), on the low side, and the stated range covers the measured number.
By their numbers in this assay, from the lowest: compound 2; then compounds 1, 4 and 3 (each within the scatter of the next, the first and the last beyond it).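

In this assay compounds 1 and 4 cannot be told apart (a 1.2-fold higher number from compound 1 to compound 4 (0.09 log units; within the scatter)), so at this carbon para to a large group, methyl and hydrogen give numbers within the scatter of each other. The phenyl group of compound 4 likewise cannot be separated from the 2,4-difluorophenyl group of compound 3 (a 1.9-fold lower number from compound 3 to compound 4 (0.27 log units; within the scatter)). Within the data shown here, the 6-fluoropyridin-2-yl group does stand apart from phenyl (a 2.5-fold higher number from compound 2 to compound 4 (0.40 log units; beyond the scatter)), which leaves compound 2 as the only compound of the four whose steps to all the others are beyond the scatter.

The data shown give no reason for this separation. Going by these compounds, it remains open whether a methoxy group, an amine or a carboxylic acid at the carbon that carries the methyl would stay within the scatter, and whether an unsubstituted pyridin-2-yl group would match the 6-fluoropyridin-2-yl group of compound 2.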